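Swapping the Acyl Ring: From Compound 3 to Compound 4

The compounds below may be only part of what the source reports. "The series", "measured", "known", "first", "only" and "open" are said of these compounds alone.

Three compounds were measured in an assay on cells for positive allosteric modulation of Cystic fibrosis transmembrane conductance regulator variant F508del (Homo sapiens), with stated times of 10 min and 7 s, in the presence of a further agent that is not named here; on this read-out higher numbers stand for an effect only at larger amounts of compound and lower numbers for an effect already at smaller amounts. Compound 1 `Cc1ccc(C(=O)Nc2sc3c(c2C(N)=O)CCCC3)s1` gave 652 nM, compound 2 `Cc1ccc(C(=O)Nc2sc3c(c2C(N)=O)CCOC3)s1` gave 778 nM, and compound 3 `CC1(C)Cc2c(sc(NC(=O)c3cccnc3O)c2C(N)=O)C(C)(C)O1` gave 190 nM. Compound 3 thus holds the lowest of the three numbers, and its gaps to compound 1 and to compound 2 both lie beyond the usual scatter. Compound 4 `CC1(C)Cc2c(sc(NC(=O)c3cn[nH]c3)c2C(N)=O)C(C)(C)O1` has not yet been measured in this assay. It differs from compound 3 in one place: 1H-pyrazol-4-yl in place of 2-hydroxypyridin-3-yl on a carbonyl carbon. Among the measured compounds shown here, no measured pair shows the effect of such a swap, so the expectation rests on compound 3 alone. The step is expected a 2.1-fold higher number from compound 3 to compound 4 (0.32 log units; beyond the scatter) to be modest and toward a higher number, possibly within the scatter. Compound 4 is therefore expected to give about 400 nM in this assay, within a range of 130 nM to 1300 nM.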

Compound 4, half-maximal effective concentration: 125 nM
For compound 4 the middle estimate is 3.2-fold (0.51 log units) above the measured one; the measured number lies below the stated range.
By their numbers in this assay, from the lowest: compounds 4 and 3 (each within the scatter of the next); then compounds 1 and 2 (each within the scatter of the next).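

In this assay, replacing 2-hydroxypyridin-3-yl with 1H-pyrazol-4-yl on the carbonyl carbon gives a 1.5-fold lower number from compound 3 to compound 4 (0.18 log units; within the scatter), so at this position a six-membered ring with an oxygen-bearing substituent and a five-membered ring with two ring nitrogens cannot be told apart. The oxygen of the departing group is therefore not needed to keep the number within the scatter of compound 3. Nothing available explains this outcome. From the compounds shown here alone, whether a 1-methylpyrazol-4-yl or a plain phenyl ring would fare the same here remains open. The compounds shown also do not reveal whether this swap would read the same on the core of compound 1.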